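From 4-methoxyphenyl to 2-nitrophenyl on the sulfonyl sulfur

A few compounds are considered here, and "the series" means these few. Any claim that something is new, unique, unknown or untested is made for them only; others in the source may bear on it.

compound 1 `O=C(/C=C/c1c[nH]c2ccccc12)c1ccncc1`: 49300 nM
compound 2 `COc1ccc(S(=O)(=O)n2cc(/C=C/C(=O)c3ccncc3)c3ccccc32)cc1`: 26000 nM
compound 3 `O=C(/C=C/c1cn(S(=O)(=O)c2cccc3ccccc23)c2ccccc12)c1ccncc1`: 62900 nM

All three values come from a functional assay on HepG2 cells (Homo sapiens) for antiproliferative activity, read by MTT assay, with a stated time of 48 h; a lower number here means a stronger inhibitor, a higher number a weaker inhibitor. Compound 2 and compound 1 lie within the scatter of each other, so neither can be ranked over the other. The one clear gap that involves compound 2 is a 2.4-fold higher number from compound 2 to compound 3 (0.38 log units; beyond the scatter), where naphthalen-1-yl takes the place of 4-methoxyphenyl on a sulfonyl sulfur.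

Compound 4 `O=C(/C=C/c1cn(S(=O)(=O)c2ccccc2[N+](=O)[O-])c2ccccc12)c1ccncc1` has not yet been measured. It changes the same place on compound 2, with 2-nitrophenyl in place of 4-methoxyphenyl on a sulfonyl sulfur.

For the measured compounds named here, only one measured step replaces this group, and it is modest: a 2.4-fold higher number from compound 2 to compound 3 (0.38 log units; beyond the scatter). Going by the values given here, no measured compound carries 2-nitrophenyl, so that single step offers only a weak guide to direction and size. In this assay, a small move toward a higher number is therefore expected, probably staying within the scatter. The expected step is a 1.5-fold higher number from compound 2 to compound 4 (0.19 log units; within the scatter). For compound 4 the estimate is 40000 nM, with an expected range from 18000 nM to 90000 nM.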

Compound 4, half-maximal inhibitory concentration: 31700 nM
Beside the measured number, compound 4's estimate is 1.3-fold (0.10 log units) above it; the range from low to high includes it.
By their numbers in this assay, from the lowest: compounds 2, 4, 1 and 3 (each within the scatter of the next, the first and the last beyond it).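

In this assay, the replacement of the 4-methoxyphenyl group on the sulfonyl sulfur by 2-nitrophenyl gives a 1.2-fold higher number from compound 2 to compound 4 (0.09 log units; within the scatter), and the replacement of naphthalen-1-yl at the same place gives a 2.0-fold lower number from compound 3 to compound 4 (0.30 log units; within the scatter), so 2-nitrophenyl cannot be ranked against either group. The earlier compounds shown here offered a single step at this place, one that lay beyond the scatter and could be read as a real difference between 4-methoxyphenyl and naphthalen-1-yl; compound 4 now falls within the scatter of both compound 2 and compound 3, which shows that the three groups form a continuous band rather than two separate levels, even though the two ends of that band remain distinguishable. No measured property of these compounds bears on the result, so the numbers show only how the values lie, not what lies behind them.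

Going by these compounds, all three groups at this place contain a six-membered aromatic ring of carbon only, so it remains open whether a group without such a ring, such as a short alkyl chain, would leave the number in this band. On these data alone, it is equally open whether a 4-aminophenyl or 4-carboxyphenyl group on the sulfonyl sulfur would move the number clearly beyond it.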